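Swapping Cyclopentyl for Benzyl at the Edge of Detection

A few compounds are considered here, and "the series" means these few. Any claim that something is new, unique, unknown or untested is made for them only; others in the source may bear on it.

Four compounds share a common core: compound 1 is `CNC(=O)C1CCCC1n1cnc2c(NC3CCCC3)ncnc21`, compound 2 is `CNC(=O)C1CC=CC1n1cnc2c(NC3CCCC3)ncnc21`, compound 3 is `CNC(=O)C1CCCC1n1cnc2c(NCc3ccccc3)ncnc21` and compound 4, not yet measured, is `CNC(=O)C1CC=CC1n1cnc2c(NCc3ccccc3)ncnc21`. The difference between the cores of compound 1 and compound 2 is not broken down here. In an assay on cell membranes for displacement of a labelled ligand from adenosine receptor A1 (Rattus norvegicus), tested at 100 uM (on this read-out higher numbers stand for more inhibition at the one concentration tested (going by the name of the read-out) and lower numbers for less inhibition), compound 1 gives 31%. Compound 3 gives 26% in this assay. For compound 2 the result in this assay is a limit of the assay, < 10%; this value is the limit of < 10% in this assay, at which 1 of the 3 values shown sits. The change benzyl in place of cyclopentyl on a nitrogen on an aromatic ring produced a number 5 percentage points lower from compound 1 to compound 3 (within the scatter). The same change turns compound 2 into compound 4: benzyl in place of cyclopentyl on a nitrogen on an aromatic ring. For the measured compounds named here, since compound 2 already sits at the limit and the one measured instance of this change stayed within the scatter, compound 4 is expected to remain at or near that limit. The step expected is a step that the limit leaves unreadable from compound 2 to compound 4, because the same change gave a number 5 percentage points lower from compound 1 to compound 3 (within the scatter). Compound 4 is estimated at 8% in this assay, most likely between 0% and 20%, with a real chance that only a limit is reported again.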

Compound 4, a percentage reported as inhibition, at one concentration (the size of the read-out at that concentration, not a potency): < 10%
Compound 4 was reported as a limit; the forecaster's own chance of this, stated with the estimate: 65%; the middle value lies beyond the limit too.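

In this assay compound 2 and compound 4 are both reported only as a limit, so the step between them, benzyl in place of cyclopentyl, cannot be read: the limit of < 10% in this assay, at which 2 of the 4 values shown sit. The compounds shown leave open whether this change does anything at all on the core of compound 2, and what the actual inhibition of either compound is.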